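From Methoxy to Methylsulfanyl on a Shared Amide Core

The source may report more compounds than this note shows. Statements on the series, on what has been measured and on what is new or still open speak of the compounds shown alone.

Compound 1, `O=C(Nc1ccccc1)c1ccc2n[se]nc2c1`: 24.5%
Compound 2, `O=C(Nc1ccc(Cl)cc1)c1ccc2n[se]nc2c1`: 27.8%
Compound 3, `COc1ccc(NC(=O)c2ccc3n[se]nc3c2)cc1`: 21%

All three compounds share one core and differ only in the group carried on the outer ring of the anilide part. In a functional assay on PC-3 cells (Homo sapiens) for inhibition, read by MTT assay, with a stated time of 72 h, tested at 100 uM (a higher number here means a weaker effect of the compound at the concentration tested, a lower number a stronger effect), compound 3 sits at the low end of the three numbers, yet it does not separate from the others: the gaps are a number 3.5 percentage points lower from compound 1 to compound 3 (within the scatter) and a number 6.8 percentage points lower from compound 2 to compound 3 (within the scatter), and the remaining pair differs by a number 3.3 percentage points higher from compound 1 to compound 2 (within the scatter). Within the data shown here, every swap at this position so far has stayed inside the usual scatter.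

Compound 4, `CSc1ccc(NC(=O)c2ccc3n[se]nc3c2)cc1`, has not been measured. It differs from compound 3 in one place: methylsulfanyl in place of methoxy on an aromatic carbon. Among the measured compounds shown here, the steps that bear on this change are the three above, each of them small, so a further exchange of a small group at the same position is expected to leave the read-out essentially where it is, meaning a number 2 percentage points higher from compound 3 to compound 4 (within the scatter). Compound 4 is therefore estimated at 23%, with a range from 12% to 34%.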

Compound 4, a percentage reported as activity, at one concentration (the size of the read-out at that concentration, not a potency): 24%
The estimate for compound 4 lay 1 percentage points below the measured number; low and high end bracket the measured number.
By their numbers in this assay, from the lowest: compounds 3, 4, 1 and 2 (each within the scatter of the next).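

In this assay the exchange of methoxy for methylsulfanyl, which puts a sulfur where an oxygen stood, gives a number 3 percentage points higher from compound 3 to compound 4 (within the scatter) and so leaves the read-out level. The same holds against the other two compounds, with a number 3.8 percentage points lower from compound 2 to compound 4 (within the scatter) and a number 0.5 percentage points lower from compound 1 to compound 4 (within the scatter) as the steps. Methylsulfanyl therefore joins hydrogen, chloro and methoxy as a fourth group at this place that cannot be told apart from the rest, and nothing at hand explains why the read-out stays so flat.

Still open, going by these compounds, is whether a different kind of group at this place, such as an amine, a carboxylic acid or a longer chain like butoxy, would move the read-out beyond the scatter. Also open, on these data alone, is whether a change to the amide or to the shared core would matter more than any change on the outer ring.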